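Removing the bromo from compound 1

The source may report more compounds than this note shows. Statements on the series, on what has been measured and on what is new or still open speak of the compounds shown alone.

Measured in a functional assay on U-251 cells (Homo sapiens) for inhibition, read by spectrophotometry and sulforhodamine B assay, with a stated time of 48 h; a higher number here means a weaker inhibitor of growth, a lower number a stronger inhibitor of growth:
- compound 1 `Cc1ccc(N2C(=O)CS/C2=N/N=C/c2c[nH]c3ccc(Br)cc23)cc1`: 54700 nM
- compound 2 `S=C(N/N=C/c1c[nH]c2ccc(Br)cc12)Nc1cccc2ccccc12`: 7320 nM
- compound 3 `Cc1ccc(NC(=S)N/N=C/c2c[nH]c3ccccc23)cc1`: 8110 nM

Compound 1 gives 54700 nM, the highest number of the three and beyond the scatter from both others, so it is the weakest inhibitor of growth measured so far. Compound 4 `Cc1ccc(N2C(=O)CS/C2=N/N=C/c2c[nH]c3ccccc23)cc1` is not yet measured. It differs from compound 1 by hydrogen in place of bromo on an aromatic carbon.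

Within the data shown here, no measured pair isolates this change. Compound 2 carries the bromo and gives 7320 nM, while compound 3 lacks it and gives 8110 nM. These two values lie within the scatter of each other, although the compounds also differ elsewhere. On that slim evidence, no step beyond the scatter is expected in this assay. The estimated change is a 1.1-fold lower number from compound 1 to compound 4 (0.04 log units; within the scatter). Compound 4 is expected at 50000 nM, with an estimated range of 20000 nM to 120000 nM.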

Compound 4, concentration for 50% growth inhibition: 90200 nM
Compound 4: the middle estimate sits 1.8-fold (0.26 log units) below what was measured; the measured number falls inside the stated range.
By their numbers in this assay, from the lowest: compounds 2 and 3 (each within the scatter of the next); then compounds 1 and 4 (each within the scatter of the next).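

In this assay, among these compounds, the first matched pair at this position gives a 1.6-fold higher number from compound 1 to compound 4 (0.22 log units; within the scatter) for hydrogen in place of bromo on an aromatic carbon. Among the compounds shown here, on the core of compound 1, the bromo can therefore be replaced by hydrogen without a change that this assay resolves, a reading that the earlier compounds could not give, as they also differ elsewhere. No measurement on hand offers an explanation for this result.

Still open, as far as these compounds go, is whether a methoxy, an amine or a carboxylic acid in this place on the core of compound 1 would also stay within the scatter of the bromo. Also open, from the compounds shown here alone, is whether the same exchange of bromo for hydrogen would give a similar step on the structures of compound 2 and compound 3.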